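The source may hold more compounds than are shown below. What is called first, only, known or untested is meant among the compounds shown, and "the series" means these compounds.

Measured in a functional assay on NCI-H522 cells (Homo sapiens) for cytotoxicity, with a stated time of 3 days; on this read-out higher numbers stand for weaker inhibition and lower numbers for stronger inhibition:
- compound 1 `C#Cc1nc2ccccc2s1`: 860 nM
- compound 2 `C=Cc1csc(Br)n1`: > 40000 nM, a limit
- compound 3 `CC#Cc1nc(C(=O)OCC)cs1`: > 40000 nM, a limit

For the measured compounds named here, compound 1 carries the only actual number of the three. The other two values stand at the limit of > 40000 nM in this assay, at which 2 of the 3 values shown sit.

Compound 4 `Ic1nc2ccccc2s1` keeps the core of compound 1 and changes one group: iodo in place of ethynyl on an aromatic carbon. Going by the values given here, no measured step covers this change, so the expectation rests on compound 1 alone, at 860 nM. Weaker inhibition beyond the usual scatter is expected, possibly reaching the limit of the assay, and the estimated change is a 9.3-fold higher number from compound 1 to compound 4 (0.97 log units; beyond the scatter). Compound 4 is estimated at 8000 nM, with an expected range of 1500 nM to 40000 nM.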

Compound 4, half-maximal inhibitory concentration: > 40000 nM
Compound 4 was reported as a limit (the forecaster's own chance of this, stated with the estimate: 35%); middle value at least 5.0-fold (0.69 log units) from the limit.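

For compound 4, > 40000 nM is a limit and not a number. At this position, on an aromatic carbon next to the ring nitrogen and next to the ring sulfur, iodo in place of ethynyl gives an at least 46-fold higher number from compound 1 to compound 4 (1.66 log units; beyond the scatter), so of the two groups shown on the core of compound 1, only ethynyl gives a measured number. Most of the series now sits at the ceiling: the limit of > 40000 nM in this assay, at which 3 of the 4 values shown sit.

Going by these compounds, the full size of the step remains unknown. Also open, on these data alone, is whether a nitrile or an amine at this position would give a measured number, as ethynyl does.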